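The source may report more compounds than this note shows. Statements on the series, on what has been measured and on what is new or still open speak of the compounds shown alone.

Three analogues of one natural-product-like core have been tested in a functional assay on MCF7 cells (Homo sapiens) for antiproliferative activity, read by MTT assay, with a stated time of 48 h; a higher number here means a weaker inhibitor, a lower number a stronger inhibitor. Compound 1 `CC(=O)OC/C1=C/C[C@](C)(CCC=C(C)C)/C=C/[C@@H](OC(=O)C=C(C)C)[C@](C)(OC(C)=O)/C=C/C1=O` gives 3990 nM. Compound 2 `CC(C)=CCC[C@]1(C)/C=C/[C@@H](OC(=O)C=C(C)C)[C@](C)(O)/C=C/C(=O)/C(CN(C(C)C)C(C)C)=C\C1` gives 780 nM, the lowest of the three numbers and therefore the strongest inhibitor here, beyond the scatter of both neighbours. Compound 3 `CC(C)=CCC[C@]1(C)/C=C/[C@@H](OC(=O)C=C(C)C)[C@](C)(O)/C=C/C(=O)/C(C[Si](c2ccccc2)(c2ccccc2)C(C)(C)C)=C\C1` gives 15800 nM. The next step changes compound 2 into compound 4 `CSC(=S)OC/C1=C/C[C@](C)(CCC=C(C)C)/C=C/[C@@H](OC(=O)C=C(C)C)[C@](C)(O)/C=C/C1=O`, in which (a group of 5 heavy atoms (2 carbon, 1 oxygen, 2 sulfur; no ring) in place of a group of 7 heavy atoms (6 carbon, 1 nitrogen; no ring), on a saturated chain carbon bound to a double-bonded ring carbon). For the measured compounds named here, no measured pair shows this exact change, so its effect can only be guessed from the spread of the three values. A weakening is expected, the step from compound 2 to compound 4 being estimated at a 3.8-fold higher number from compound 2 to compound 4 (0.59 log units; beyond the scatter). In this assay compound 4 is expected to give about 3000 nM, somewhere between 1000 nM and 10000 nM.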

Compound 4, half-maximal inhibitory concentration: 900 nM
Compound 4: middle estimate off by 3.3-fold (0.52 log units), on the high side, outside the stated range (below it).
By their numbers in this assay, from the lowest: compounds 2 and 4 (each within the scatter of the next); then compound 1; then compound 3.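

Swapping diisopropylamino for the group of compound 4, on a saturated chain carbon bound to a double-bonded ring carbon, gives in this assay a step of a 1.2-fold higher number from compound 2 to compound 4 (0.06 log units; within the scatter) and leaves the two compounds indistinguishable. This place therefore carries two very different groups, one with nitrogen and the other with oxygen and sulfur, with numbers that lie within the scatter of each other. Nothing measured here explains this result. From the compounds shown here alone, whether a carboxylic acid or a longer chain on this carbon would give a similar number remains open. Going by these compounds, a smaller amine, such as dimethylamino, is an equally open case.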